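A few compounds are considered here, and "the series" means these few. Any claim that something is new, unique, unknown or untested is made for them only; others in the source may bear on it.

Measured in a functional assay on A549 cells (Homo sapiens) for antiproliferative activity, read by MTT assay, with a stated time of 72 h (on this read-out lower numbers stand for stronger inhibition and higher numbers for weaker inhibition), so far:
- compound 1 `CCC/C=C/C(=O)Nc1cccc(Oc2nc(Nc3ccn(C)n3)nc3c2CSCC3)c1` gives 8190 nM
- compound 2 `C=C(F)C(=O)Nc1cccc(Oc2nc(Nc3ccn(C)n3)nc3c2CSCC3)c1` gives > 50000 nM as a limit of the assay, not a number
- compound 3 `CCC/C=C/C(=O)Nc1cccc(Oc2nc(Nc3cccc(OC)c3)nc3c2CSCC3)c1` gives 11800 nM

Compound 3 stands within the scatter of compound 1, with a 1.4-fold higher number from compound 1 to compound 3 (0.16 log units; within the scatter) as the step between them. Compound 4 `C=C(F)C(=O)Nc1cccc(Oc2nc(Nc3cccc(OC)c3)nc3c2CSCC3)c1` has 1-fluoroethenyl in place of pent-1-en-1-yl on a carbonyl carbon. Compound 2 carries the same exchange, and its step is an at least 6.1-fold higher number from compound 1 to compound 2 (0.78 log units; beyond the scatter) and rests on the limit of > 50000 nM in this assay, at which 1 of the 3 values shown sits, as its end point. A higher number beyond the scatter is therefore expected in this assay for compound 4, which may also return only a limit. The expected move is a 3.8-fold higher number from compound 3 to compound 4 (0.58 log units; beyond the scatter) on this estimate. Compound 4 is estimated at 45000 nM with an expected range from 20000 nM to 80000 nM in this read-out.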

Compound 4, half-maximal inhibitory concentration: 29600 nM
For compound 4 the middle estimate is 1.5-fold (0.18 log units) above the measured one; the range from low to high includes it.
By their numbers in this assay, from the lowest: compounds 1 and 3 (each within the scatter of the next); then compound 4. At a limit, above all of these: compound 2.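

In this assay, 1-fluoroethenyl in place of pent-1-en-1-yl on a carbonyl carbon now has a measured, modest size on the core carrying 3-methoxyphenyl: a 2.5-fold higher number from compound 3 to compound 4 (0.40 log units; beyond the scatter). Compound 2 gives > 50000 nM, a limit of the assay and not a number. Read from that limit, 3-methoxyphenyl in place of 1-methyl-1H-pyrazol-3-yl on a nitrogen on an aromatic ring gives an at least 1.6-fold lower number from compound 2 to compound 4 (0.22 log units; that floor lies within the scatter). The exchange points to weaker inhibition on both cores, with its size readable only on one: the same change on two cores in this assay, an at least 6.1-fold higher number (0.78 log units; beyond the scatter) from compound 1 to compound 2 and a 2.5-fold higher number (0.40 log units; beyond the scatter) from compound 3 to compound 4; the limit leaves it open whether they differ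

Going by these compounds, whether the two cores differ in this step stays open. Also open, on these data alone, is how a longer chain, or a chain ending in an amine, on this carbonyl carbon would read in this assay.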